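The source may hold more compounds than are shown below. What is called first, only, known or untested is meant among the compounds shown, and "the series" means these compounds.

Measured so far:
compound 1, `Nc1ccc2c(c1)/C(=C1\C(=O)Nc3ccccc31)C(=O)N2`: 25000 nM
compound 2, `O=C1Nc2cc([N+](=O)[O-])ccc2/C1=C1/Nc2ccccc2C1=O`: 15000 nM

The account concerns two indolinone-type compounds tested in a functional assay on PC-3 cells (Homo sapiens) for antiproliferative activity, with a stated time of 72 h; on this read-out higher numbers stand for weaker inhibition and lower numbers for stronger inhibition. Compound 1 gives 25000 nM, the highest of the two numbers; compound 2 gives 15000 nM, and the gap between compound 1 and compound 2 lies within the scatter, so the two cannot be told apart on this read-out.

The next compound, compound 3, `O=C1Nc2ccccc2/C1=C1\C(=O)Nc2ccc([N+](=O)[O-])cc21`, is not yet measured. It differs from compound 1 as follows: nitro in place of amino on an aromatic carbon. Among the compounds with values here, no step between measured compounds covers this change. Since compound 2 also carries a nitro and sits close to compound 1, only a small step is expected, a 1.7-fold lower number from compound 1 to compound 3 (0.22 log units; within the scatter), if any beyond the scatter. Compound 3 is therefore estimated at 15000 nM, with a range from 5000 nM to 45000 nM.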

Compound 3, half-maximal inhibitory concentration: > 25000 nM
Compound 3 was reported as a limit (the forecaster's own chance of this, stated with the estimate: 10%); middle value at least 1.6-fold (0.22 log units) from the limit.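

In this assay compound 3 is reported only as the limit > 25000 nM and not as a number. On this aromatic carbon, nitro in place of amino therefore brings no gain: the change gives a number no lower from compound 1 to compound 3 (the limit leaves the size open) and so supplies the first step among these compounds, which the earlier pair could not offer. The size of this step cannot be read because the result is a limit: the limit of > 25000 nM in this assay, at which 1 of the 3 values shown sits.

The compounds shown leave open how far compound 3 lies from compound 1, and so whether this change matters at all beyond the usual scatter. They also leave open how a plain hydrogen, a methoxy group or a carboxylic acid on the same aromatic carbon would read in this assay and whether any of these would give a lower number than amino.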